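The source may report more compounds than this note shows. Statements on the series, on what has been measured and on what is new or still open speak of the compounds shown alone.

Compound 1 `Cc1ccc(-c2onc3ccc(/C=C/C(=O)O)cc23)cc1` gives 6510 nM in an assay for inhibition of inositol hexakisphosphate kinase 2 (Homo sapiens), read by colorimetric assay, coupled enzyme assay and malachite green, with a stated time of 120 min, in the presence of a further agent that is not named here; on this read-out lower numbers stand for stronger inhibition and higher numbers for weaker inhibition; compound 2 `O=C(O)c1ccc2noc(-c3ccc(Cc4ccccc4)cc3)c2c1` gives 65 nM in this assay.

Of these two numbers compound 2 has the lowest, and its nearest neighbour, compound 1, stands at a higher number, a gap beyond the usual scatter. Compound 3 `O=C(O)c1ccc2noc(-c3ccc(Oc4ncc(Cl)cc4Cl)cc3)c2c1` differs from compound 2 in one place: (3,5-dichloropyridin-2-yl)oxy in place of benzyl on an aromatic carbon. For the measured compounds named here, no measured pair shows a comparable exchange, so there is no step to lean on. One aromatic-ring-bearing group is swapped for another at the same aromatic carbon. The step is expected to stay within the usual scatter, a 1.2-fold higher number from compound 2 to compound 3 (0.09 log units; within the scatter). Compound 3 is estimated at 80 nM, with a range from 25 nM to 300 nM.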

Compound 3, half-maximal inhibitory concentration: 650 nM
Compound 3: the middle estimate sits 8.1-fold (0.91 log units) below what was measured; the whole stated range lies below it.
By their numbers in this assay, from the lowest: compound 2; then compound 3; then compound 1.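

This position, on a six-membered aromatic ring of carbon only and para to a large group, does not treat all ring-bearing groups alike. In this assay, (3,5-dichloropyridin-2-yl)oxy in place of benzyl gives a 10-fold higher number from compound 2 to compound 3 (1.00 log units; beyond the scatter) and so costs real inhibition. The change brings in a linking oxygen, a ring nitrogen and two chlorine atoms at once, and nothing measured here tells which of them matters. Going by these compounds, it remains open whether a plain phenoxy group, with neither the ring nitrogen nor the chlorines, would stand nearer compound 2 or compound 3.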